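Cytotoxicity notes: from compound 2 to compound 3

The compounds below may be only part of what the source reports. "The series", "measured", "known", "first", "only" and "open" are said of these compounds alone.

Measured so far in an ADME assay on MRC5 cells (Homo sapiens) for cytotoxicity, read by fluorescence and resazurin assay, with a stated time of 3 days; a lower number here means a stronger inhibitor, a higher number a weaker inhibitor
- Compound 1 `Cc1cccc(Oc2cccc(CN3CCC(n4cc(C)c(=O)[nH]c4=O)CC3)c2)c1` gives > 64000 nM as a limit of the assay
- Compound 2 `Cc1cn(C2CCN(Cc3cccc(Oc4cccc(OC(F)(F)F)c4)c3)CC2)c(=O)[nH]c1=O` gives 5260 nM as a number

For the measured compounds named here, compound 2 holds the only actual number, and the other entry is the limit of > 64000 nM in this assay, at which 1 of the 2 values shown sits, with no number behind it. Compound 3 `Cc1cn(C2CCN(Cc3cccc(Oc4ccc(Cl)c(C(F)(F)F)c4)c3)CC2)c(=O)[nH]c1=O` is next to be measured. It carries 4-chloro-3-(trifluoromethyl)phenyl in place of 3-(trifluoromethoxy)phenyl on an oxygen on an aromatic ring is the counted difference.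

Going by the values given here, one measured step bears on this change. The step of an at least 12-fold lower number from compound 1 to compound 2 (1.08 log units; beyond the scatter) is large, lies beyond the scatter and starts from a limit. It shows that a change on this same aromatic ring can move the number a long way. Among the compounds with values here, that step replaces methyl, however, and no measured step exchanges one fluorine-bearing group for another, so its guidance is loose. Expected in this assay is a 1.5-fold lower number from compound 2 to compound 3 (0.18 log units; within the scatter) with a slight lean to a lower number but nothing clearly beyond the scatter. Compound 3 is estimated at 3500 nM with an expected range from 1300 nM to 10000 nM for now.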

Compound 3, half-maximal inhibitory concentration: 5280 nM
Compound 3: the middle estimate sits 1.5-fold (0.18 log units) below what was measured, within the range that was stated.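

In this assay, the exchange of 3-(trifluoromethoxy)phenyl for 4-chloro-3-(trifluoromethyl)phenyl on an oxygen on an aromatic ring gives a 1.0-fold higher number from compound 2 to compound 3 (0.00 log units; within the scatter), so this position accepts two differently substituted rings with values that lie within the scatter of each other. Against the 3-methylphenyl ring the new ring gives an at least 12-fold lower number from compound 1 to compound 3 (1.08 log units; beyond the scatter), so the large step first seen with 3-(trifluoromethoxy)phenyl now appears with a second ring, and among the three compounds the 3-methylphenyl ring of compound 1 is the one that stands apart. Compound 1 holds the one entry that is a limit and not a number, so the full size of that step stays unknown: the limit of > 64000 nM in this assay, at which 1 of the 3 values shown sits.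

Going by these compounds, with chlorine and trifluoromethyl entering together in compound 3, what each contributes alone remains open, as does whether a ring carrying only one of them would stay with compound 2 and compound 3 or move towards compound 1. Also open, on these data alone, is how the read-out in this assay would respond to an amine or a carboxylic acid on this ring.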